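A few compounds are considered here, and "the series" means these few. Any claim that something is new, unique, unknown or untested is made for them only; others in the source may bear on it.

Among the compounds with values here, compound 2 `c1ccc2c(c1)CN[C@@H](CN(CCCCNCC1CCCCC1)[C@H]1CCCc3cccnc31)C2` gives 158 nM in a functional assay on cells for antagonist activity at C-X-C chemokine receptor type 4 (Homo sapiens), read by fluorescence and calcium flux, with stated times of 25 min and 90 s (on this read-out higher numbers stand for weaker inhibition and lower numbers for stronger inhibition), and is the only compound with a number on this read-out. Compound 1 `c1ccc(CN(CCCCN(C[C@H]2Cc3ccccc3CN2)[C@H]2CCCc3cccnc32)Cc2ccccc2)cc1` sits at a limit of this assay, > 16700 nM, which is not a number. Compound 3 `c1ccc2c(c1)CN[C@@H](CN(CCCCNC1CCCCC1)[C@H]1CCCc3cccnc31)C2` differs from compound 2 by cyclohexyl in place of cyclohexylmethyl on an amine nitrogen. Within the data shown here, no measured pair shows this change, so the step in this assay is expected to be small, at most a slight weakening, as a 1.6-fold higher number from compound 2 to compound 3 (0.20 log units; within the scatter). Compound 3 is therefore expected at 250 nM, within 80 nM to 800 nM.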

Compound 3, half-maximal inhibitory concentration: 75.2 nM
Compound 3: middle estimate off by 3.3-fold (0.52 log units), on the high side; measured number below the stated range.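

In this assay, cyclohexyl in place of cyclohexylmethyl on an amine nitrogen gives a 2.1-fold lower number from compound 2 to compound 3 (0.32 log units; beyond the scatter). This shows that the position responds to a change as small as this one and that the ring can sit directly on the nitrogen without loss of inhibition. Compound 1 supplies no number to set against this, as its value is a limit: the limit of > 16700 nM in this assay, at which 1 of the 3 values shown sits.

As far as these compounds go, whether a smaller ring such as cyclopentyl, an open chain such as butyl, or an aromatic phenyl on this nitrogen would hold or extend the gain remains open.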